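From dimethylpiperazine to methylpiperazine on a shared core

The compounds below may be only part of what the source reports. "The series", "measured", "known", "first", "only" and "open" are said of these compounds alone.

Compound 1 `C[C@@H]1CN(c2cccc3c2C[C@H](CN(C)[C@H]2CCCc4cccnc42)NC3)C[C@H](C)N1`: > 30000 nM
Compound 2 `CC(C)N(C[C@H]1Cc2c(cccc2N2CCNCC2)CN1)[C@H]1CCCc2cccnc21`: > 30000 nM

In a functional assay on CCRF-CEM cells for agonist activity at C-X-C chemokine receptor type 4 (Homo sapiens), read by calcium flux, with a stated time of 25 min (on this read-out lower numbers stand for an effect already at smaller amounts and higher numbers for an effect only at larger amounts of compound), compound 1 gives > 30000 nM, and this is a limit of the assay rather than a number. In the same assay compound 2 gives > 30000 nM, which is again a limit and not a number. Among the measured compounds shown here, compound 1 therefore stands at the limit, and the one further value shown sits there as well: the limit of > 30000 nM in this assay, at which 2 of the 2 values shown sit. For the measured compounds named here, no step between two measured compounds with a single point of difference is available, so nothing is known about how large a change in this assay a single alteration of the core produces.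

Compound 3 `CN1CCN(c2cccc3c2C[C@H](CN(C)[C@H]2CCCc4cccnc42)NC3)CC1` differs from compound 1 in one place: 4-methylpiperazin-1-yl in place of 3,5-dimethylpiperazin-1-yl on an aromatic carbon. Since both measured compounds sit at the limit of this assay, compound 3 is expected to sit there too, and the step of a number no higher from compound 1 to compound 3 (the limit leaves the size open) is estimated as none beyond the scatter. For compound 3 the expected value in this assay is 30000 nM, with a range from 10000 nM to 100000 nM, most likely reported as a limit.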

Compound 3, half-maximal effective concentration: > 30000 nM
Compound 3: only a limit was reported; the forecaster's own chance of this, stated with the estimate: 85%; the middle value lies on the limit itself.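

Compound 1 and compound 3 both stand at a limit of this assay rather than at a number, so no step can be read between them: the limit of > 30000 nM in this assay, at which 3 of the 3 values shown sit.

The compounds shown leave open whether any alteration of the shared core brings a measurable effect in this assay, and how far 4-methylpiperazin-1-yl and 3,5-dimethylpiperazin-1-yl differ there.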